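From a Sulfur Chain to a Hydroxyethoxy Chain on Compound 2

The compounds below may be only part of what the source reports. "The series", "measured", "known", "first", "only" and "open" are said of these compounds alone.

Of the compounds shown here, two that share one core have been measured in a functional assay on ileum for inhibition of histamine H1 receptor (Cavia porcellus); a higher number here means a weaker inhibitor, a lower number a stronger inhibitor. Compound 1 `CCNCCn1c(N2CCN(C)CC2)nc2ccccc21` gives 290 nM in this assay, and compound 2 `CCCSCn1c(N2CCN(C)CC2)nc2ccccc21` gives 68 nM. Within the data shown here, the single measured step, a 4.3-fold lower number from compound 1 to compound 2 (0.63 log units; beyond the scatter), leaves compound 2 with the lower of the two numbers. Compound 3 `CN1CCN(c2nc3ccccc3n2CCOCCO)CC1` awaits measurement in this assay; it differs from compound 2 by (2-hydroxyethoxy)methyl in place of propylsulfanyl on a saturated chain carbon bound to an aromatic nitrogen. The step from compound 1 to compound 2 sits at the same place and shows that swapping this side chain can move the number beyond the scatter. The entering group resembles neither earlier chain closely, and one step gives no pattern; the direction of the coming step is open, though a weakening is the more likely reading. Compound 3 is therefore expected to give 200 nM, a step of a 2.9-fold higher number from compound 2 to compound 3 (0.47 log units; beyond the scatter), within a range from 60 nM to 700 nM.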

Compound 3, half-maximal inhibitory concentration: 42 nM
Compound 3: the middle estimate sits 4.8-fold (0.68 log units) above what was measured; measured number outside the range, below it.
By their numbers in this assay, from the lowest: compounds 3 and 2 (each within the scatter of the next); then compound 1.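

In this assay, the exchange of propylsulfanyl for (2-hydroxyethoxy)methyl gives a 1.6-fold lower number from compound 2 to compound 3 (0.21 log units; within the scatter), so this position takes either chain without a change that can be told from the scatter, even though the two chains share little beyond their size. The second step, a 6.9-fold lower number from compound 1 to compound 3 (0.84 log units; beyond the scatter), sets the 2-hydroxyethoxy chain clearly apart from the ethylamino chain, which leaves compound 1 alone with the higher number among the three. No measurement shown here accounts for this difference. Still open, as far as these compounds go, is whether a 2-methoxyethoxy chain would give a number like that of compound 3, which would test the role of the hydroxy group. Also open, from the compounds shown here alone, is how a carboxylic acid, a dimethylamino group or a longer chain would fare at this position.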